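The source may hold more compounds than are shown below. What is called first, only, known or untested is meant among the compounds shown, and "the series" means these compounds.

Two compounds of a shared core have been examined in an ADME assay on Vero cells (Chlorocebus sabaeus) for cytotoxicity, read by MTT assay, with a stated time of 72 h (a lower number here means a stronger inhibitor, a higher number a weaker inhibitor), and a third awaits testing. Compound 1 `CCCCc1nc(Cl)c(C2NC(=O)NC(C)=C2C(=O)Nc2ccccc2)[nH]1` has no reported result in this assay: "not determined" (no result reported). Compound 2 `CCCCc1nc(Cl)c(C2NC(=O)NC(C)=C2C(=O)Nc2ccccc2F)[nH]1` gives > 10 ug/mL in this assay, which is a limit of the assay and not a number. Within the data shown here, compound 2 therefore stands at the limit described by the limit of > 10 ug/mL in this assay, at which 1 of the 2 values shown sits, and the only other entry carries no number either, so no step between measured compounds can be read.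

Compound 3 `CCCCc1nc(Cl)c(C2NC(=O)NC(C)=C2C(=O)Nc2ccccc2Cl)[nH]1` differs from compound 2 by chloro in place of fluoro on an aromatic carbon. Among the measured compounds shown here, with no measured step to lean on, the expectation for this assay is a step of none beyond the scatter, and compound 3 is expected to stay near where compound 2 sits. Compound 3 is estimated at 15 ug/mL, within a range from 6 ug/mL to 40 ug/mL, which amounts to an expected step that the limit leaves unreadable from compound 2 to compound 3.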

Compound 3, half-maximal inhibitory concentration: 7.6 ug/mL
Compound 3: middle estimate off by 2.0-fold (0.30 log units), on the high side; the measured number falls inside the stated range.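

Among these compounds, compound 3 gives the first actual number in this set, so this place, on an aromatic carbon ortho to a large group, can now be read in this assay rather than only bounded by a limit. Chloro in place of fluoro here gives an at least 1.3-fold lower number from compound 2 to compound 3 (0.11 log units; that floor lies within the scatter), which means the data show only a floor that does not clear the usual spread of repeat measurements. The true size of the step stays unknown because compound 2 carries a limit and not a number: the limit of > 10 ug/mL in this assay, at which 1 of the 3 values shown sits.

Compound 1, which has neither chloro nor fluoro at this place, has no result, so the effect of either group against the unsubstituted ring cannot be read. Also open, going by these compounds, is how a methoxy group or an amine at the same place would compare with chloro.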